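Three amides, then an ester, on a shared thiazole core

The source may report more compounds than this note shows. Statements on the series, on what has been measured and on what is new or still open speak of the compounds shown alone.

Compound 3 `CCN(CC)C(=O)c1sc(-c2ccc(Cl)cc2)nc1C(Br)Br` was tested in an ADME assay on BHK15 cells (Mesocricetus auratus) for inhibition, read by XTT assay, with a stated time of 36 h (a lower number here means a stronger inhibitor of growth, a higher number a weaker inhibitor of growth), and gives 63500 nM. Among the three measured compounds its number is the lowest, but only by margins that the scatter of the method swallows: compound 2 `CNC(=O)c1sc(-c2ccc(Cl)cc2)nc1C(Br)Br` gives 74600 nM in this assay, and compound 1 `CONC(=O)c1sc(-c2ccc(Cl)cc2)nc1C(Br)Br` gives 81400 nM. The step of a 1.2-fold lower number from compound 2 to compound 3 (0.07 log units; within the scatter) and the step of a 1.3-fold lower number from compound 1 to compound 3 (0.11 log units; within the scatter) both lie within that scatter, so these three cannot be ranked against one another.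

Compound 4 `CC(C)OC(=O)c1sc(-c2ccc(Cl)cc2)nc1C(Br)Br` differs from compound 3 in one place: isopropoxy in place of diethylamino on a carbonyl carbon. The measured steps that bear on this position are those between the three amides, a 1.1-fold lower number from compound 1 to compound 2 (0.04 log units; within the scatter), a 1.3-fold lower number from compound 1 to compound 3 (0.11 log units; within the scatter) and a 1.2-fold lower number from compound 2 to compound 3 (0.07 log units; within the scatter), none of which moved the number beyond the scatter. Among the measured compounds shown here, no measured compound carries an ester here, so the data give no direction for this particular swap. The expectation is therefore no change beyond the scatter, a step of a 1.0-fold higher number from compound 3 to compound 4 (0.01 log units; within the scatter) in this assay. Compound 4 is estimated to give 65000 nM, within a range from 25000 nM to 170000 nM.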

Compound 4, concentration for 50% growth inhibition: 372000 nM
Beside the measured number, compound 4's estimate is 5.7-fold (0.76 log units) below it; the measured number lies above the stated range.
By their numbers in this assay, from the lowest: compounds 3, 2 and 1 (each within the scatter of the next); then compound 4.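

In this assay this position on the carbonyl carbon proves sensitive after all: the three amides stay within the scatter of one another, but the ester compound 4 stands apart from each of them. The step of a 5.9-fold higher number from compound 3 to compound 4 (0.77 log units; beyond the scatter) and the step of a 5.0-fold higher number from compound 2 to compound 4 (0.70 log units; beyond the scatter) and the step of a 4.6-fold higher number from compound 1 to compound 4 (0.66 log units; beyond the scatter) all run the same way, which makes compound 4 the weakest inhibitor of growth of the four, though each step is only modest. Nothing measured alongside these numbers accounts for the shift.

Going by these compounds, whether this belongs to esters in general or to isopropoxy alone remains open, and a methyl ester or an ethyl ester at the same place would help separate the two. A carboxylic acid on this carbonyl carbon is also an open case.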